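Swapping Cyclopropylmethyl for Phenyl: Expected Microsomal Clearance

The source may report more compounds than this note shows. Statements on the series, on what has been measured and on what is new or still open speak of the compounds shown alone.

Compound 1, `O=C(NCc1cc(Cl)ccc1-n1cnnn1)[C@@H]1C[C@@H]2C[C@@H]2N1C(=O)[C@H](O)CC1CC1`: < 12 mL.min-1.g-1
Compound 2, `O=C(NCc1cc(Cl)ccc1-n1cnnn1)[C@@H]1C[C@H]2C[C@H]2N1C(=O)[C@H](O)CC1CC1`: 25 mL.min-1.g-1
Compound 3, `O=C(NCc1cc(Cl)ccc1-n1cnnn1)[C@@H]1CC=NN1C(=O)[C@H](O)C1CCCCC1`: 63 mL.min-1.g-1

Of the compounds shown here, three on a shared core have been tested in an ADME assay on liver for metabolic stability, with Liver microsome (Homo sapiens) as the target, read by LC-MS, using microsomes; on this read-out higher numbers stand for fast clearance and lower numbers for slow clearance. For compound 1 the result is a limit of the assay rather than a number: compound 1 gives < 12 mL.min-1.g-1, which is the limit of < 12 mL.min-1.g-1 in this assay, at which 1 of the 3 values shown sits. In this assay compound 2 gives 25 mL.min-1.g-1, and compound 3 gives 63 mL.min-1.g-1. Among the measured compounds shown here, the one step that can be read in full is an at least 2.0-fold higher number from compound 1 to compound 2 (0.31 log units; beyond the scatter), and what sets the pair apart is the fact that compounds 1 and 2 differ only in the configuration as drawn. Compound 3 differs from compound 1 in more than one place, so its value only shows where it lies.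

Compound 4, `O=C(NCc1cc(Cl)ccc1-n1cnnn1)[C@@H]1C[C@@H]2C[C@@H]2N1C(=O)[C@H](O)c1ccccc1`, has not yet been measured. The change from compound 1 is phenyl in place of cyclopropylmethyl on a saturated chain carbon bound to a carbonyl carbon and an oxygen on a saturated carbon. For the measured compounds named here, none of the measured steps touches this part of the molecule: the step from compound 1 to compound 2 alters only the drawn configuration of the core, and compound 3 carries a different core together with a different group at that place. Going by these compounds, compound 1 itself stands at a limit, so its exact number is unknown. With nothing bearing directly on the change, the step expected for compound 4 is an at least 1.1-fold higher number from compound 1 to compound 4 (0.06 log units; that floor lies within the scatter), held loosely. Compound 4 is estimated at 14 mL.min-1.g-1, between 6 mL.min-1.g-1 and 40 mL.min-1.g-1.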

Compound 4, intrinsic clearance in microsomes: < 16 mL.min-1.g-1
Compound 4 ended at the assay's limit; the forecaster's own chance of this, stated with the estimate: 40%; the middle value lies beyond the limit too.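

Compound 1 and compound 4 both ended at a limit of this assay rather than at an exact number, so the step between them cannot be read. The compounds shown leave open whether phenyl in place of cyclopropylmethyl changes the clearance at all, and, if it does, in which direction and by how much.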